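Chloro for Methyl in Two Aminopyrazole Series

The source may report more compounds than this note shows. Statements on the series, on what has been measured and on what is new or still open speak of the compounds shown alone.

Compound 1 `Cc1ccc(-c2cc(N)n(-c3ccc(Br)cc3)n2)cc1` and compound 2 `Nc1cc(-c2ccc(Cl)cc2)nn1-c1ccc(Br)cc1` differ by chloro in place of methyl on an aromatic carbon. In a functional assay on NPC-TW01 cells (Homo sapiens) for inhibition, read by MTT assay, with a stated time of 72 h (on this read-out higher numbers stand for weaker inhibition of growth and lower numbers for stronger inhibition of growth), compound 1 gives 80200 nM, and compound 2 gives 64400 nM; the step is a 1.2-fold lower number from compound 1 to compound 2 (0.10 log units; within the scatter). Compound 3 `Cc1ccc(-c2cc(/N=C/N(C)C)n(-c3cccc(Cl)c3)n2)cc1` carries a formamidine in place of the free amine and a different aryl on the pyrazole nitrogen; how its core differs from the core of compound 1 is not broken down here. For compound 3 this assay reports only a limit, > 100000 nM, not a number, as it does (the limit of > 100000 nM in this assay, at which 1 of the 3 values shown sits). Compound 4 `CN(C)/C=N/c1cc(-c2ccc(Cl)cc2)nn1-c1cccc(Cl)c1` is related to compound 3 by the same kind of change, (chloro in place of methyl on an aromatic carbon). Given a 1.2-fold lower number from compound 1 to compound 2 (0.10 log units; within the scatter), compound 4 is expected to sit near compound 3, a step of a number no higher from compound 3 to compound 4 (the limit leaves the size open), with the estimate for compound 4 being 100000 nM (from 50000 nM to 200000 nM) and a limit again likely.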

Compound 4, concentration for 50% growth inhibition: 92700 nM
Beside the measured number, compound 4's estimate is 1.1-fold (0.03 log units) above it; low and high end bracket the measured number.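

On the core of compound 3, the change from 4-methylphenyl to 4-chlorophenyl gives an at least 1.0-fold lower number from compound 3 to compound 4 (0.03 log units; that floor lies within the scatter) in this assay. Set beside the step on the core of compound 1, the result reads as follows: the same change on two cores in this assay, a 1.2-fold lower number (0.10 log units; within the scatter) from compound 1 to compound 2 and an at least 1.0-fold lower number (0.03 log units; that floor lies within the scatter) from compound 3 to compound 4; the limit leaves it open whether they differ

Neither pair shows a step beyond the scatter, which fits the change carrying over with little effect on these two cores. Compound 3 has only a limit, however, so the size of its step stays unfixed, and two pairs establish no rule for the series.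

The compounds shown leave open whether fluoro, methoxy or trifluoromethyl at the same place would behave like chloro. They also leave open what the formamidine alone does to the free amine's value, as it changes together with the other aryl group between compound 1 and compound 3.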